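Adding a Phenylethenyl Group to a Weak Ketone

This account rests on a few compounds, and the source may have more. Where it says the series, first, only, none or still open, it means among the compounds named here.

In a functional assay on MIA PaCa-2 cells (Homo sapiens) for cytotoxicity, read by resazurin assay, with a stated time of 72 h (a lower number here means a stronger inhibitor, a higher number a weaker inhibitor), compound 3 (`COCOc1cc(OC)cc(OC)c1C(C)=O`) gives > 20000 nM, which is a limit of the assay and not a number. The change to compound 4 (`COCOc1cc(OC)cc(OC)c1C(=O)/C=C/c1ccccc1`) puts 2-phenylethenyl in place of methyl on a carbonyl carbon. Among the compounds with values here, no measured step covers this exact change.

The nearest guide is compound 1 (`COc1cc(OC)c(C(=O)/C=C/c2ccccc2)c(OC)c1`), which also carries 2-phenylethenyl on a carbonyl carbon. Compound 1 gives > 20000 nM, again a limit. So both compounds rest at the limit of > 20000 nM in this assay, at which 2 of the 3 values shown sit.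

Compound 2 (`C=CCOc1ccccc1Cc1c(OC)cc(OC)c(C(=O)/C=C/c2ccccc2)c1OC`), which has 2-(allyloxy)benzyl in place of hydrogen on an aromatic carbon, gives 9400 nM. Within the data shown here, the one measured step is an at least 2.1-fold lower number from compound 1 to compound 2 (0.32 log units; beyond the scatter), and it involves a group that compound 4 lacks. It therefore offers no support for a large gain.

In this assay, only a small drop in the number is expected, possibly none beyond the scatter. The estimated step is an at least 1.1-fold lower number from compound 3 to compound 4 (0.04 log units; that floor lies within the scatter). For compound 4 the expected value is 18000 nM, with an estimated range of 7000 nM to 35000 nM.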

Compound 4, half-maximal inhibitory concentration: 5600 nM
For compound 4 the middle estimate is 3.2-fold (0.51 log units) above the measured one, and the stated range ends above it.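

In this assay, within the data shown here, 2-phenylethenyl on the carbonyl carbon gives a gain beyond the scatter, an at least 3.5-fold lower number from compound 3 to compound 4 (0.55 log units; beyond the scatter), which none of the earlier compounds could show. A second, smaller-looking change also counts: methoxy in place of hydrogen on a saturated chain carbon bound to an oxygen on an aromatic ring gives an at least 3.5-fold lower number from compound 1 to compound 4 (0.55 log units; beyond the scatter), so carrying 2-phenylethenyl is not enough on its own. Each of these steps starts from a limit, and its full size stays unknown: the limit of > 20000 nM in this assay, at which 2 of the 4 values shown sit.

The ring and the double bond of 2-phenylethenyl enter together, so the compounds shown do not separate what each one contributes. As far as these compounds go, it also remains open whether a longer saturated chain or an amine on the same carbonyl carbon would give a similar result.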